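Chain extension step from compound 3 to compound 4

This account rests on a few compounds, and the source may have more. Where it says the series, first, only, none or still open, it means among the compounds named here.

Measured in a functional assay on PC-3 cells (Homo sapiens) for inhibition, read by MTT assay, with a stated time of 48 h (a lower number here means a stronger inhibitor, a higher number a weaker inhibitor), for the series
Compound 1 `O=C(CCCCCCOc1ccc(-c2nc3ccc(-c4nc5ccccc5[nH]4)cc3[nH]2)cc1)NO` gives 4400 nM
Compound 2 `O=C(CCCCCCCOc1cccc(-c2nc3ccc(-c4nc5ccccc5[nH]4)cc3[nH]2)c1)NO` gives 6900 nM
Compound 3 `O=C(CCCCCCOc1cccc(-c2nc3ccccc3[nH]2)c1)NO` gives 2700 nM

Compound 3 at 2700 nM and compound 1 lie within the scatter of each other, so no order is drawn between them. Compound 2 at 6900 nM stands beyond the scatter from compound 3 with the higher number.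

Compound 4 `O=C(CCCCCCCOc1cccc(-c2nc3ccccc3[nH]2)c1)NO` has not yet been measured. Its difference from compound 3 is (hydroxycarbamoyl)methyl in place of hydroxycarbamoyl on a saturated chain carbon, six bonds along the chain from an oxygen on an aromatic ring with (hydroxycarbamoyl)methyl in place of hydroxycarbamoyl on a saturated chain carbon, six bonds along the chain from an oxygen on an aromatic ring. For the measured compounds named here, no two measured compounds differ in one place only, so the series holds no direct measure of this change.

In this assay no step beyond the scatter is expected in either direction, and this expectation takes compound 3 at 2700 nM as its starting point. The estimated step is a 1.2-fold higher number from compound 3 to compound 4 (0.07 log units; within the scatter) and it stays within the scatter. Compound 4 is estimated at 3200 nM with an expected range from 1400 nM to 7200 nM for the measurement.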

Compound 4, half-maximal inhibitory concentration: 7900 nM
For compound 4 the middle estimate is 2.5-fold (0.39 log units) below the measured one; the measured number lies above the stated range.
By their numbers in this assay, from the lowest: compounds 3, 1, 2 and 4 (each within the scatter of the next, the first and the last beyond it).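

In this assay, for the compounds shown here, (hydroxycarbamoyl)methyl in place of hydroxycarbamoyl on a saturated chain carbon, six bonds along the chain from an oxygen on an aromatic ring, gives a 2.9-fold higher number from compound 3 to compound 4 (0.47 log units; beyond the scatter) and is the first direct reading of this position, showing that the series responds to this change in chain length beyond the scatter. Going by these compounds alone, the other new pair, hydrogen in place of 1H-benzimidazol-2-yl on an aromatic carbon, gives a 1.1-fold higher number from compound 2 to compound 4 (0.06 log units; within the scatter) and adds a first direct reading at that second place, where the two compounds with the (hydroxycarbamoyl)methyl chain end stay within the scatter of each other. Nothing on hand accounts for either step.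

Open, going by these compounds, is whether the same chain change reads alike on the larger core of compound 2, and whether the 1H-benzimidazol-2-yl group is equally without a step beyond the scatter on the hydroxycarbamoyl chain end of compound 3. Also open, on these data alone, are a still longer chain ending in 2-(hydroxycarbamoyl)ethyl or 3-(hydroxycarbamoyl)propyl at this place, a shorter chain, and a carboxylic acid at the chain end in place of the hydroxycarbamoyl group.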